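A few compounds are considered here, and "the series" means these few. Any claim that something is new, unique, unknown or untested is made for them only; others in the source may bear on it.

Measured so far:
Compound 1 `O=S(=O)(NCCNCc1cccc2ccccc12)c1cc(C(F)(F)F)cc(C(F)(F)F)c1` — 22000 nM
Compound 2 `O=S(=O)(NCCCNCC1COc2ccccc2O1)c1cc(C(F)(F)F)cc(C(F)(F)F)c1` — 2900 nM

The two measured compounds share a core and differ in both the linking chain and the group on the saturated chain carbon bound to the amine nitrogen. In a functional assay on ASPC1 cells (Homo sapiens) for inhibition, read by MTT assay, with a stated time of 72 h (on this read-out lower numbers stand for stronger inhibition of growth and higher numbers for weaker inhibition of growth), compound 2 gives 2900 nM, the lowest of the two numbers, and compound 1 gives 22000 nM; the gap between them lies beyond the scatter.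

Compound 3 `O=S(=O)(NCCCNCc1cccc(Cl)c1)c1cc(C(F)(F)F)cc(C(F)(F)F)c1` keeps the chain of compound 2 and changes only the group at the end: 3-chlorophenyl in place of 2,3-dihydro-1,4-benzodioxin-2-yl on a saturated chain carbon bound to an amine nitrogen. Going by the values given here, no measured pair shows this change, so its effect cannot be read from the numbers at hand. Given that compound 2 stands at 2900 nM, the step of a 1.7-fold higher number from compound 2 to compound 3 (0.24 log units; within the scatter) in this assay is expected to be modest, toward a somewhat higher number, and possibly within the scatter. Compound 3 is therefore estimated at 5000 nM, with a range from 1500 nM to 20000 nM.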

Compound 3, concentration for 50% growth inhibition: 5900 nM
Compound 3: middle estimate off by 1.2-fold (0.07 log units), on the low side, within the range that was stated.
By their numbers in this assay, from the lowest: compound 2; then compound 3; then compound 1.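

With the linking chain held fixed, the end group can now be read on its own: in this assay, 3-chlorophenyl in place of 2,3-dihydro-1,4-benzodioxin-2-yl on a saturated chain carbon bound to an amine nitrogen gives a 2.0-fold higher number from compound 2 to compound 3 (0.31 log units; beyond the scatter) and so weakens growth inhibition only modestly. Compound 3 shows that inhibition persists at this place with a group that has a single aromatic ring of carbon only and no hydrogen-bond acceptors. No measurement at hand accounts for this step.

The compounds shown leave open whether the chlorine contributes at all, as an unsubstituted phenyl or a methoxy group in its stead would test. Nor can the part played by the chain be read, since compound 1 differs from both other compounds in its chain and in its end group.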